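The compounds below may be only part of what the source reports. "The series", "measured", "known", "first", "only" and "open" are said of these compounds alone.

In a functional assay on SW-620 cells (Homo sapiens) for cytotoxicity, read by MTT assay, with stated times of 4 h and 72 h, tested at 5 uM (on this read-out higher numbers stand for weaker inhibition and lower numbers for stronger inhibition), compound 1 `Cc1cc(Nc2ccc(C(=O)/C=C/c3ccc4ccccc4c3)cc2)n2nc(SCc3ccccc3Br)nc2n1` gives 420 nM and compound 2 `Cc1cc(Nc2ccc(C(=O)/C=C/c3ccc4ccccc4c3)cc2)n2nc(SCc3ccc(Br)cc3)nc2n1` gives 370 nM on the same read-out, so the two stand level. Compound 3 `COc1ccc(CSc2nc3nc(C)cc(Nc4ccc(C(=O)/C=C/c5ccc6ccccc6c5)cc4)n3n2)cc1` has methoxy in place of bromo on an aromatic carbon, para to a large group (methoxy in place of bromo on an aromatic carbon). Among the measured compounds shown here, the only measured step that bears on this is a 1.1-fold lower number from compound 1 to compound 2 (0.06 log units; within the scatter) when 4-bromophenyl replaces 2-bromophenyl. That step tested no new group, so the data offer only weak guidance, and no change beyond the scatter is expected. The expected step is a 1.1-fold higher number from compound 2 to compound 3 (0.03 log units; within the scatter) in this assay here. For compound 3 the estimate is 400 nM with 180 nM to 900 nM as the expected range.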

Compound 3, half-maximal inhibitory concentration: 250 nM
Compound 3: the middle estimate sits 1.6-fold (0.20 log units) above what was measured; measured number inside the range.
By their numbers in this assay, from the lowest: compounds 3, 2 and 1 (each within the scatter of the next).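

In this assay, methoxy, the first group other than bromo at this spot, gives a 1.5-fold lower number from compound 2 to compound 3 (0.17 log units; within the scatter), and the change from 2-bromophenyl to 4-methoxyphenyl gives a 1.7-fold lower number from compound 1 to compound 3 (0.23 log units; within the scatter). So a different group, with one more heavy atom and one hydrogen-bond acceptor, leaves all three compounds level on this read-out. Nothing measured here offers an explanation for this. On these data alone, whether an amine, a carboxylic acid or a longer chain in place of methoxy would also leave the number within the scatter remains open, as does how 2-methoxyphenyl would compare.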